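Caffeic ester anilides: chloro to methoxy on the anilide ring

This account rests on a few compounds, and the source may have more. Where it says the series, first, only, none or still open, it means among the compounds named here.

Measured so far:
compound 1, `COCOc1ccc(/C=C/C(=O)N2CCN(Cc3ccc(Cl)c(Cl)c3)CC2)cc1OCOC`, 139000 nM
compound 2, `O=C(COC(=O)/C=C/c1ccc(O)c(O)c1)Nc1ccc(Cl)cc1`, 108000 nM

Both numbers come from a functional assay on LS174T cells (Homo sapiens) for cytotoxicity, read by MTT assay, with a stated time of 72 h; on this read-out higher numbers stand for weaker inhibition and lower numbers for stronger inhibition. Compound 1 gives 139000 nM and compound 2 gives 108000 nM; the two values lie within the usual scatter of each other, so on this assay compound 2 is not set apart from compound 1, and both sit at weak inhibition.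

Compound 3, `COc1ccc(NC(=O)COC(=O)/C=C/c2ccc(O)c(O)c2)cc1`, has not yet been measured. It differs from compound 2 in one place: methoxy in place of chloro on an aromatic carbon.

Within the data shown here, no step between two measured compounds isolates this change, so there is no measured precedent for its size or direction. With compound 1 and compound 2 both at weak inhibition and no shift beyond the scatter between them, the expectation for this assay is a step from compound 2 to compound 3 of a 1.2-fold higher number from compound 2 to compound 3 (0.08 log units; within the scatter), not beyond the scatter, with no clear direction. Compound 3 is therefore expected to give about 130000 nM in this assay, within a range of 50000 nM to 350000 nM.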

Compound 3, half-maximal inhibitory concentration: 124000 nM
Compound 3: middle estimate off by 1.0-fold (0.02 log units), on the high side; the measured number falls inside the stated range.
By their numbers in this assay, from the lowest: compounds 2, 3 and 1 (each within the scatter of the next).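

In this assay, among these compounds, the exchange of 4-chlorophenyl for 4-methoxyphenyl gives a 1.1-fold higher number from compound 2 to compound 3 (0.06 log units; within the scatter) and is the first measured step at this position, where compound 1 offered no comparison. On an aromatic carbon of a six-membered aromatic ring of carbon only, para to a large group, this step does not separate chloro, with one heavy atom and no hydrogen-bond acceptor, from methoxy, with two heavy atoms and one hydrogen-bond acceptor, and both compounds remain at weak inhibition. Nothing at hand gives a reason for this outcome.

Open, going by these compounds, is whether any group at this position can move the number beyond the scatter: an amine or a carboxylic acid in place of chloro would be a sharper test than this single exchange, which stays at weak inhibition. Also open, on these data alone, is whether a change elsewhere, such as a longer chain in place of the link between the ester and the anilide nitrogen, would shift the number.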